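This account rests on a few compounds, and the source may have more. Where it says the series, first, only, none or still open, it means among the compounds named here.

Working notes on the series in a functional assay on KYSE-70 cells for antiproliferative activity against KYSE-70 cell line (Homo sapiens), read by MTT assay, with a stated time of 72 h; on this read-out lower numbers stand for stronger inhibition and higher numbers for weaker inhibition. Compound 1 (`COc1ccccc1NC(=O)c1ccnc2cc(Br)ccc12`) reads > 20000 nM, a limit of the assay and not a number. Compound 2 (`O=C(Nc1ccc(Cl)cc1)c1cc(=O)[nH]c2cc(Br)ccc12`) reads > 20000 nM, again a limit. Compound 3 (`O=C(Nc1cccc(F)c1)c1cc(=O)[nH]c2cc(-c3ccccc3)ccc12`) reads > 20000 nM, also a limit, so it has no number of its own. Within the data shown here, the series so far stands at the limit of > 20000 nM in this assay, at which 3 of the 3 values shown sit. Compound 4 (`Cc1ccc(-c2ccc3c(C(=O)Nc4cccc(F)c4)cc(=O)[nH]c3c2)cc1`) differs from compound 3 in one place, phenyl to 4-methylphenyl, with methyl in place of hydrogen on an aromatic carbon. Among the measured compounds shown here, no measured pair shows the size of such a change in this assay, so no shift beyond the scatter is expected, in either direction. The expected step, a number no higher from compound 3 to compound 4 (the limit leaves the size open), is an estimate anchored only on that limit. For compound 4 the estimated value is 20000 nM, with an expected range of 8000 nM to 40000 nM.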

Compound 4, half-maximal inhibitory concentration: > 20000 nM
Compound 4 gave a limit, no number (the forecaster's own chance of this, stated with the estimate: 65%); the middle value lies on the limit itself.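

No step can be read from compound 3 to compound 4, as each reads only as a limit: the limit of > 20000 nM in this assay, at which 4 of the 4 values shown sit.

The compounds shown leave open how large an effect methyl in place of hydrogen on an aromatic carbon has in this series.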